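Hydroxy for hydrogen at the trifluoro carbinol of compound 1

The source may report more compounds than this note shows. Statements on the series, on what has been measured and on what is new or still open speak of the compounds shown alone.

Compound 1 `O=C(CCCCCCNC(=O)C(O)C(F)(F)F)Nc1nccs1` was run in a functional assay on HCT-116 cells (Homo sapiens) for inhibition, read by colorimetric assay, with a stated time of 3 days; a lower number here means a stronger inhibitor, a higher number a weaker inhibitor. In this assay compound 1 gives only a limit, > 40000 nM, and no number. Compound 2 `O=C(CCCCCCNC(=O)C(O)(O)C(F)(F)F)Nc1ccc(C(=O)c2ccccc2)cc1` gives only a limit in this assay too, > 40000 nM. Compound 3 `CC(=O)C(=O)NCCCCCC(=O)Nc1ccccc1` also gives only a limit in this assay, > 100000 nM. So compound 1 stands at a limit shared with compound 2 (the limit of > 40000 nM in this assay, at which 2 of the 3 values shown sit), while compound 3 sits at a higher limit (the limit of > 100000 nM in this assay, at which 1 of the 3 values shown sits); none of the three yields a number, so compound 1 cannot be ranked further.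

Compound 4 `O=C(CCCCCCNC(=O)C(O)(O)C(F)(F)F)Nc1nccs1` differs from compound 1 by hydroxy in place of hydrogen on a saturated chain carbon bound to a carbonyl carbon, an oxygen on a saturated carbon and a saturated chain carbon. Among the measured compounds shown here, no measured pair shows this change. Compound 2 carries the same 2,2,2-trifluoro-1,1-dihydroxyethyl group and gave only the limit already noted. In this assay the expected step is a step that the limit leaves unreadable from compound 1 to compound 4, nothing beyond the scatter. Compound 4 is estimated at 60000 nM, between 30000 nM and 150000 nM, most likely again only a limit.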

Compound 4, half-maximal inhibitory concentration: 10800 nM
Beside the measured number, compound 4's estimate is 5.6-fold (0.74 log units) above it, and the stated range ends above it.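

Hydroxy in place of hydrogen at this carbon is the first change in the series to reach a measured number, giving an at least 3.7-fold lower number from compound 1 to compound 4 (0.56 log units; beyond the scatter). The size of this step is only a minimum, as compound 1 gives a limit and not a number. The 2,2,2-trifluoro-1,1-dihydroxyethyl group is not enough by itself, as compound 2 carries it and still gives only a limit: the limit of > 40000 nM in this assay, at which 2 of the 4 values shown sit.

Going by these compounds, the true size of the step stays open. So does whether an amine or a methoxy group at this carbon, or a longer chain, would keep the activity of compound 4.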